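Methoxy added to a weakly cytotoxic chromone series

A few compounds are considered here, and "the series" means these few. Any claim that something is new, unique, unknown or untested is made for them only; others in the source may bear on it.

Four related compounds are compared here for how strongly they harm a human monocyte-like cell line. Compound 1 `CC(=O)Nc1ccc2oc(-c3ccccc3)cc(=O)c2c1` and compound 2 `COc1ccccc1-c1cc(=O)c2cc(NC(C)=O)ccc2o1` share a core and differ in one spot: methoxy in place of hydrogen on an aromatic carbon. In an ADME assay on THP-1 cells (Homo sapiens) for cytotoxicity, read by flow cytometry and propidium iodide staining, with a stated time of 72 h (a higher number here means a weaker inhibitor, a lower number a stronger inhibitor), compound 1 gives 97000 nM, and compound 2 gives 50000 nM, so the methoxy brought a 1.9-fold lower number from compound 1 to compound 2 (0.29 log units; within the scatter). Compound 3 `COc1c(-c2ccccc2)oc2ccc(N)cc2c1=O` belongs to a different core; the difference between the two cores is not broken down here. In this assay compound 3 gives 74000 nM, which sits among the other two with no separation beyond scatter. Compound 4 `COc1ccccc1-c1oc2ccc(N)cc2c(=O)c1OC` has not yet been measured; it differs from compound 3 by methoxy in place of hydrogen on an aromatic carbon, the same change, at the same kind of place, that turned compound 1 into compound 2. Because the earlier step was only a 1.9-fold lower number from compound 1 to compound 2 (0.29 log units; within the scatter), the step from compound 3 to compound 4 is expected to be similarly small, about a 1.5-fold lower number from compound 3 to compound 4 (0.17 log units; within the scatter). Compound 4 is therefore estimated at around 50000 nM in this assay, plausibly between 20000 nM and 150000 nM.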

Compound 4, half-maximal inhibitory concentration: 116000 nM
For compound 4 the middle estimate is 2.3-fold (0.37 log units) below the measured one; the measured number falls inside the stated range.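

On the second core, the same methoxy change gave a 1.6-fold higher number from compound 3 to compound 4 (0.20 log units; within the scatter) in this assay. Set beside the earlier step, this shows that the change does not carry over as one fixed shift from one core to the other: the same change on two cores in this assay, a 1.9-fold lower number (0.29 log units; within the scatter) from compound 1 to compound 2 and a 1.6-fold higher number (0.20 log units; within the scatter) from compound 3 to compound 4, 3.0-fold (0.48 log units) apart, beyond the scatter of two such steps

Each step taken alone still lies within the scatter, however, and with a single pair on each core, these numbers do not show why the two steps differ or whether the gap would hold on any other core in the series.

The compounds shown leave open whether a different group in the same place, such as a hydroxyl, a fluorine or a longer ethoxy chain, would move the number beyond the scatter. They also leave open which of the differences between the two cores matters for the methoxy step, since a core that differs from the core of compound 1 in only one place does not appear among them.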